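A few compounds are considered here, and "the series" means these few. Any claim that something is new, unique, unknown or untested is made for them only; others in the source may bear on it.

Measured so far in a physicochemical assay for lipophilicity, read by HPLC, measured as chromatographic lipophilicity, at pH 7.4; on this read-out higher numbers stand for higher lipophilicity and lower numbers for lower lipophilicity:

- compound 1 `O=C(C1CCN(c2ccncn2)CC1)N1N=CC[C@H]1c1ccccc1`: 3.2
- compound 2 `O=C(c1cscn1)N1CCC(C(=O)N2N=CC[C@H]2c2ccccc2)CC1`: 3

In this assay, compound 2 at 3 lies within the usual scatter of compound 1 at 3.2. Compound 3 `Cc1nnc(N2CCC(C(=O)N3N=CC[C@H]3c3ccccc3)CC2)o1` changes compound 2 at one place: 5-methyl-1,3,4-oxadiazol-2-yl in place of (1,3-thiazol-4-yl)carbonyl on an amine nitrogen in a ring. Among the compounds with values here, only one measured step bears on this amine nitrogen, a number 0.20 log units lower from compound 1 to compound 2 (within the scatter), and it stayed within the scatter. That single step is thin evidence, but it points to no large change, so the expected step is modest, a number 0.20 log units lower from compound 2 to compound 3 (within the scatter), and not beyond the scatter. For compound 3 the estimated value is 2.8, with an expected range from 2.4 to 3.2.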

Compound 3, distribution coefficient: 3.2
Beside the measured number, compound 3's estimate is 0.40 log units below it, and the stated range covers the measured number.
By their numbers in this assay, from the lowest: compounds 2, 1 and 3 (each within the scatter of the next).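

In this assay, 5-methyl-1,3,4-oxadiazol-2-yl in place of (1,3-thiazol-4-yl)carbonyl gives a number 0.20 log units higher from compound 2 to compound 3 (within the scatter), and the same group in place of pyrimidin-4-yl gives no change at the digits printed from compound 1 to compound 3 (within the scatter). Within the data shown here, all three groups on this amine nitrogen now lie within the scatter of one another, so the read-out stays level across three different rings, where earlier only one pair could be compared. Nothing available explains this level result. Still open, from the compounds shown here alone, is whether it would hold for a group without a ring on this nitrogen, such as a carboxylic acid or a longer chain.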